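Methoxy to hydrogen on an aromatic carbon: paw edema notes

A few compounds are considered here, and "the series" means these few. Any claim that something is new, unique, unknown or untested is made for them only; others in the source may bear on it.

Compound 1 `C=CCn1c(SCC(=O)c2ccccc2)nnc1-c1ccc(OC)c(OC)c1` gives 61% in a functional assay on the whole organism (strain albino) for inhibition, with Rattus norvegicus as the target, read by paw edema, with a stated time of 1 h, at a dose of 0.28 mmol/kg by the oral route; on this read-out higher numbers stand for more inhibition at the one dose given (going by the name of the read-out) and lower numbers for less inhibition.
Compound 2 `C=CCn1c(SCC(=O)c2ccccc2)nnc1-c1ccc(OC)cc1` gives 49% in this assay.
Compound 3 `CCn1c(SC/C(=N/O)c2ccccc2)nnc1-c1cc(OC)c(OC)c(OC)c1` gives 63% in this assay.

Compound 4 `CCn1c(SC/C(=N/O)c2ccccc2)nnc1-c1ccc(OC)c(OC)c1` has not been measured yet.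

Among the measured compounds a single counted change is available: hydrogen in place of methoxy on an aromatic carbon. The step it made, a number 12 percentage points lower from compound 1 to compound 2 (beyond the scatter), is modest but lies beyond the scatter. Compound 1 and compound 3 sit within the scatter of each other, so nothing is read into their order. For the measured compounds named here, compound 3 and compound 2 are further apart: compound 2 gives 49%, whereas compound 3 gives 63%, a gap beyond the scatter; no single step is broken down for that pair. The difference between the core of compound 1 and the core of compound 3 is not broken down here.

Compound 4 relates to compound 3 by hydrogen in place of methoxy on an aromatic carbon. The surroundings of the place are not identical to the earlier change: in compound 3 the leaving methoxy is also meta to a methoxy group. It is therefore the same kind of change, not the same change.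

In this assay compound 4 is expected to give about 51%, estimated between 38% and 64%. Going by the values given here, the expected step is a number 12 percentage points lower from compound 3 to compound 4 (beyond the scatter), because a number 12 percentage points lower from compound 1 to compound 2 (beyond the scatter) is the only measured step of this kind, and the extra methoxy around the place in compound 3 adds uncertainty to the estimate.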

Compound 4, a percentage reported as inhibition, in the whole organism at one dose (the size of the read-out at that dose, not a potency): 61%
Compound 4: middle estimate off by 10 percentage points, on the low side; the measured number falls inside the stated range.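

In this assay, hydrogen in place of methoxy on an aromatic carbon gives a number 2 percentage points lower from compound 3 to compound 4 (within the scatter), so on this core the change cannot be told apart from the usual scatter. The earlier step on the other core lay beyond the scatter, but the gap between the two steps does not show that the core alters the effect of the change: the same change on two cores in this assay, a number 12 percentage points lower (beyond the scatter) from compound 1 to compound 2 and a number 2 percentage points lower (within the scatter) from compound 3 to compound 4, 10 percentage points apart, within the scatter of two such steps

For the compounds shown here, this means the two results are compatible with one shared step size, but they do not establish one: there is only a single pair on each core, the surroundings of the leaving methoxy are not identical, and a real dependence on the core of a size hidden by the scatter remains possible.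

The compounds shown leave open how other groups at this place on the six-membered aromatic ring would read in this assay, for example a hydroxy group, an amine or a longer chain such as ethoxy. They also leave open whether the small step seen on the core of compound 3 would recur with other substituents elsewhere on that ring, and which part of the difference between the two cores matters, if any does.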